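The source may report more compounds than this note shows. Statements on the series, on what has been measured and on what is new or still open speak of the compounds shown alone.

Measured in an ADME assay on L6 cells (Rattus norvegicus) for cytotoxicity; a lower number here means a stronger inhibitor, a higher number a weaker inhibitor:
- compound 1 `O=C(NCCCN1CCN(CCCNc2ccnc3cc(Cl)ccc23)CC1)c1ccc(Oc2ccccc2)cc1`: 1400 nM
- compound 2 `CCCCCC(=O)NCCCN1CCN(CCCNc2ccnc3cc(Cl)ccc23)CC1`: "not determined" (no result reported)
- compound 3 `CC(=O)CCC(=O)NCCCN1CCN(CCCNc2ccnc3cc(Cl)ccc23)CC1`: 11000 nM

Compound 3 has the higher of the two numbers, and compound 1 lies lower, beyond the scatter. The step to compound 4 `CCOc1ccc(C(=O)NCCCN2CCN(CCCNc3ccnc4cc(Cl)ccc34)CC2)cc1` is 4-ethoxyphenyl in place of 2-acetylethyl on a carbonyl carbon. Among the compounds with values here, no measured pair isolates this change. Compound 1 also has a six-membered aromatic ring of carbon only on a carbonyl carbon, so a lower number in this assay, beyond the scatter, is expected, resting on compound 1 at 1400 nM. The estimated change is a 4.4-fold lower number from compound 3 to compound 4 (0.64 log units; beyond the scatter). For compound 4 the expected value is 2500 nM, with an estimated range of 900 nM to 7000 nM.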

Compound 4, half-maximal inhibitory concentration: 5300 nM
Estimate against measurement, compound 4: 2.1-fold (0.33 log units) below; low and high end bracket the measured number.
By their numbers in this assay, from the lowest: compound 1; then compound 4; then compound 3.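

In this assay, an aromatic ring on the carbonyl carbon can now be judged against the open chain: a 2.1-fold lower number from compound 3 to compound 4 (0.32 log units; beyond the scatter) comes with 4-ethoxyphenyl in place of 2-acetylethyl. Having the ring there does not settle the number, since a 3.8-fold higher number from compound 1 to compound 4 (0.58 log units; beyond the scatter) comes with ethyl in place of phenyl on an oxygen on an aromatic ring. Nothing available explains either step.

Still open, on these data alone, is how an amine or a carboxylic acid on that aromatic ring, or a longer chain on the oxygen, would move the number.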